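Swapping chlorophenyl for aminophenyl on a weakly active core

The source may hold more compounds than are shown below. What is called first, only, known or untested is meant among the compounds shown, and "the series" means these compounds.

Compound 3 `Fc1cccc(-c2nc(Nc3cccc(Cl)c3)c3cc(F)ccc3n2)c1` reaches only a limit in a functional assay on U-937 cells (Homo sapiens) for cytotoxicity, read by MTT assay, with a stated time of 48 h; on this read-out lower numbers stand for stronger inhibition and higher numbers for weaker inhibition: compound 3 gives > 50000 nM, which is the assay limit rather than a number. Its two relatives stand close by. Compound 1 `Fc1cccc(-c2nc(Nc3ccccc3F)c3cc(F)ccc3n2)c1` likewise gives only a limit, > 50000 nM, in this assay. Compound 2 `Fc1cccc(-c2nc(Nc3ccc(Cl)cc3)c3cc(F)ccc3n2)c1` gives a number in this assay, 32700 nM. The measured steps are small: an at least 1.5-fold lower number from compound 1 to compound 2 (0.18 log units; that floor lies within the scatter), an at least 1.5-fold higher number from compound 2 to compound 3 (0.18 log units; that floor lies within the scatter), and a step that the two limits leave unreadable from compound 1 to compound 3, as the limit of > 50000 nM in this assay, at which 2 of the 3 values shown sit, shows. Compound 4 `Nc1ccccc1Nc1nc(-c2cccc(F)c2)nc2ccc(F)cc12` differs from compound 3 by 2-aminophenyl in place of 3-chlorophenyl on a nitrogen on an aromatic ring. For the measured compounds named here, since none of the measured steps is readable as beyond the scatter, no step beyond the scatter is expected in this assay, and compound 4 is estimated at 50000 nM, between 20000 nM and 150000 nM. That estimate means an expected step of a number no higher from compound 3 to compound 4 (the limit leaves the size open).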

Compound 4, half-maximal inhibitory concentration: 47300 nM
For compound 4 the middle estimate is 1.1-fold (0.02 log units) above the measured one; the measured number falls inside the stated range.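

In this assay, 2-aminophenyl in place of 3-chlorophenyl on this nitrogen gives a readable number where compound 3 reaches only a limit, yet the step shows no change beyond the scatter: an at least 1.0-fold lower number from compound 3 to compound 4 (0.02 log units; that floor lies within the scatter). The other two steps read the same way, with a 1.4-fold higher number from compound 2 to compound 4 (0.16 log units; within the scatter) and an at least 1.0-fold lower number from compound 1 to compound 4 (0.02 log units; that floor lies within the scatter). Thus chlorophenyl, fluorophenyl and aminophenyl at this place all stay within the scatter, and the assay limit bounds the comparison: the limit of > 50000 nM in this assay, at which 2 of the 4 values shown sit.

As far as these compounds go, whether a carboxylic acid or a longer chain in place of the aminophenyl would give a step beyond the scatter stays open.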